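Imidazole substitution pattern in a diphenylpropanamide series

A few compounds are considered here, and "the series" means these few. Any claim that something is new, unique, unknown or untested is made for them only; others in the source may bear on it.

Compound 2 `CCc1nccn1CCC(C(N)=O)(c1ccccc1)c1ccccc1` carries the larger number of the two measured in an assay on ileum with muscarinic acetylcholine receptor M3 (Cavia porcellus) as the target (a higher number here means a weaker inhibitor, a lower number a stronger inhibitor), giving 78.1 nM; compound 1 `c1ccc(C(CCN2CCCCC2)c2ccccc2)cc1` gives 69.6 nM, and the gap between them lies within the scatter, so the two stand together. Compound 3 `CCc1ncn(CCC(C(N)=O)(c2ccccc2)c2ccccc2)c1CC` differs from compound 2 by 4,5-diethyl-1H-imidazol-1-yl in place of 2-ethyl-1H-imidazol-1-yl on a saturated chain carbon, three bonds along the chain from two aromatic carbons and a carbonyl carbon. Among the compounds with values here, no step of this kind is on record, so its size is unknown; a modest change in either direction, or none beyond the scatter, is expected. Compound 3 is therefore estimated at 60 nM, within 20 nM to 200 nM. The expected step is a 1.3-fold lower number from compound 2 to compound 3 (0.11 log units; within the scatter).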

Compound 3, antagonist equilibrium constant: 3.98 nM
Beside the measured number, compound 3's estimate is 15-fold (1.18 log units) above it; the whole stated range lies above it.
By their numbers in this assay, from the lowest: compound 3; then compounds 1 and 2 (each within the scatter of the next).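

In this assay this saturated chain carbon proves sensitive to the imidazole substitution pattern: 4,5-diethyl-1H-imidazol-1-yl in place of 2-ethyl-1H-imidazol-1-yl gives a 20-fold lower number from compound 2 to compound 3 (1.29 log units; beyond the scatter). The ring type, hydrogen-bond counts and charge stay the same, so the step goes with the number and placement of the ethyl groups, which change together here. No measurement at hand bears on its origin.

A single ethyl group at the 4 or 5 ring position would separate these two changes. From the compounds shown here alone, whether methyl or propyl groups in place of the two ethyl groups keep the step stays open.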